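Phenyl for Methyl on the Core: Expectation for Compound 4

A few compounds are considered here, and "the series" means these few. Any claim that something is new, unique, unknown or untested is made for them only; others in the source may bear on it.

Three compounds share a hydroxamic acid attached through a piperidine to a bicyclic core. In an assay on isolated protein for inhibition of protein deacetylase HDAC6 (Homo sapiens), read by fluorescence, with a stated time of 30 min (on this read-out higher numbers stand for weaker inhibition and lower numbers for stronger inhibition), compound 1 `COc1cc2c(NCC3CCN(c4ccc(C(=O)NO)cc4)CC3)cc(-c3ccc(C)o3)nc2cc1OCCCN1CCCC1` gives 67 nM. Compound 2 `COc1cc2c(NCC3CCN(c4ncc(C(=O)NO)cn4)CC3)cc(C)nc2cc1OCCCN1CCCC1` gives 350 nM in this assay, and compound 3 `COc1cc2nc(C)cc(NCC3CCN(c4ncc(C(=O)NO)cn4)CC3)c2cc1OC` gives 253 nM. For the measured compounds named here, the only single-point step among them is a 1.4-fold lower number from compound 2 to compound 3 (0.14 log units; within the scatter). Compound 3 thus stands second highest of the three numbers, within the scatter of compound 2 and beyond the scatter of compound 1.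

Compound 4 `COc1cc2nc(-c3ccccc3)cc(NCC3CCN(c4ncc(C(=O)NO)cn4)CC3)c2cc1OC` differs from compound 3 in one place: phenyl in place of methyl on an aromatic carbon. Going by the values given here, no measured step changes this position alone; compound 1 carries an aromatic ring at the same place but differs from compound 3 in several other places as well, so its lower number cannot be attributed to that ring. Among the compounds with values here, the one measured step, from compound 2 to compound 3, concerns a different site and falls within the scatter. For compound 4 in this assay a step of a 1.4-fold lower number from compound 3 to compound 4 (0.15 log units; within the scatter) is therefore expected, not beyond the scatter. Compound 4 is estimated at 180 nM, with a range from 70 nM to 450 nM.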

Compound 4, half-maximal inhibitory concentration: 230 nM
Estimate against measurement, compound 4: 1.3-fold (0.11 log units) below, within the range that was stated.
By their numbers in this assay, from the lowest: compound 1; then compounds 4, 3 and 2 (each within the scatter of the next).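

In this assay, phenyl in place of methyl on this aromatic carbon, next to the ring nitrogen, gives a step (a 1.1-fold lower number from compound 3 to compound 4 (0.04 log units; within the scatter)) that stays within the scatter. For the compounds shown here, this is the first reading of this position with nothing else altered, and it shows that the site holds a six-membered aromatic ring of carbon only with no measurable difference from methyl in this compound pair. No evidence is at hand on why the two groups read alike here.

The compounds shown leave open whether an amine, such as aminomethyl, or a carboxylic acid at this aromatic carbon would read the same. Going by these compounds alone, also open is how much the aromatic ring at this place contributes to the number of compound 1 (67 nM), as no single-place pair isolates it.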